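The source may hold more compounds than are shown below. What is called first, only, known or untested is meant among the compounds shown, and "the series" means these compounds.

Working notes on the series in a functional assay on MCF7 cells (Homo sapiens) for antiproliferative activity, read by MTT assay, with a stated time of 24 h; a higher number here means a weaker inhibitor, a lower number a stronger inhibitor.

Compound 1 `Fc1ccc(C2CC(c3ccccc3)=NN2c2ccc(-c3ccccc3)nn2)cc1` gives 100000 nM. Compound 2 `FC(F)(F)c1ccc(C2CC(c3ccccc3)=NN2c2ccc(-c3ccccc3)nn2)cc1` gives 100000 nM, and the step of no change at the digits printed from compound 1 to compound 2 (within the scatter) shows the trifluoromethyl-for-fluoro exchange leaving the number unchanged. Compound 3 `COc1ccc(C2CC(c3ccccc3)=NN2c2ccc(-c3ccccc3)nn2)c(OC)c1` is reported only as a limit in this assay, > 100000 nM. The limit is described by the limit of > 100000 nM in this assay, at which 1 of the 3 values shown sits. The steps of a number no lower from compound 1 to compound 3 (the limit leaves the size open) and a number no lower from compound 2 to compound 3 (the limit leaves the size open) can therefore give no readable size.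

On the numbers shown, compound 2 stands level with compound 1, and every value in this assay sits at or beyond the same high level, so the measured steps all read as no change or as open limits.

Compound 4 `COc1ccc(C2=NN(c3ccc(-c4ccccc4)nn3)C(c3ccc(C(F)(F)F)cc3)C2)cc1` differs from compound 2 by methoxy in place of hydrogen on an aromatic carbon. Within the data shown here, no measured step in this assay exchanges a hydrogen for a methoxy at that position; the closest comparison, compound 3, shows only that added methoxy groups elsewhere did not lower the number. Compound 4 is therefore expected to show no step beyond the scatter, no change at the digits printed from compound 2 to compound 4 (within the scatter). The estimate for compound 4 is 100000 nM, within 40000 nM to 100000 nM.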

Compound 4, half-maximal inhibitory concentration: 46800 nM
Compound 4: the middle estimate sits 2.1-fold (0.33 log units) above what was measured; the range from low to high includes it.
By their numbers in this assay, from the lowest: compound 4; then compounds 1 and 2 (each within the scatter of the next).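

Among these compounds, the change from phenyl to 4-methoxyphenyl gives a 2.1-fold lower number from compound 2 to compound 4 (0.33 log units; beyond the scatter) in this assay, the first readable step that lies beyond the scatter, though it is modest. The earlier changes, all on the aryl group at the saturated ring carbon, gave either no change or an open result, so this aromatic carbon on the other aryl group is the first place shown where a substitution moves the number. The steps ending at compound 3 still cannot be read, as that compound remains a limit: the limit of > 100000 nM in this assay, at which 1 of the 4 values shown sits.

On these data alone, it remains open whether the same methoxy gives a comparable step on compound 1. As far as these compounds go, it is also open whether a hydroxyl, an amine or a longer chain such as ethoxy at this carbon would lower the number further.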